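The source may report more compounds than this note shows. Statements on the series, on what has been measured and on what is new or still open speak of the compounds shown alone.

Measured compounds:
- compound 1, `O=c1cc(CSC(=S)N2CCCC2)oc2ccccc12`: 23100 nM
- compound 2, `O=c1cc(CSC(=S)N2CCCC2)oc2cc(Cl)ccc12`: > 40000 nM
- compound 3, `CC(C)N(C(=S)SCc1coc2ccccc2c1=O)C(C)C`: > 30000 nM

All three were run in a functional assay on HeLa cells (Homo sapiens) for antiproliferative activity, read by MTT assay, with a stated time of 72 h; on this read-out higher numbers stand for weaker inhibition and lower numbers for stronger inhibition. Compound 1 gives 23100 nM in this assay. For compound 2 this assay returns only a limit, > 40000 nM, and not a number; see (the limit of > 40000 nM in this assay, at which 1 of the 3 values shown sits). For compound 3 this assay likewise returns only a limit, > 30000 nM, and not a number; see (the limit of > 30000 nM in this assay, at which 1 of the 3 values shown sits).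

The measured step from compound 1 to compound 2 is chloro in place of hydrogen on an aromatic carbon, and in this assay it gives an at least 1.7-fold higher number from compound 1 to compound 2 (0.23 log units; that floor lies within the scatter). The same change is now applied to compound 3, giving the unmeasured compound 4, `CC(C)N(C(=S)SCc1coc2cc(Cl)ccc2c1=O)C(C)C`: chloro in place of hydrogen on an aromatic carbon. The place lines of the two changes are identical word for word, so the change is the same, not merely the same kind. The difference between the core of compound 1 and the core of compound 3 is not broken down here.

Compound 3 already sits at a limit in this assay, so the step to compound 4 can only be stated as an expectation. The expected step is a step that the limit leaves unreadable from compound 3 to compound 4, resting on the measured step of an at least 1.7-fold higher number from compound 1 to compound 2 (0.23 log units; that floor lies within the scatter) and on the fact that compound 3 gives only the limit > 30000 nM. Compound 4 is therefore expected to give about 60000 nM in this assay, between 30000 nM and 150000 nM, and most likely this assay will report only a limit for compound 4 rather than a number.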

Compound 4, half-maximal inhibitory concentration: > 25000 nM
Compound 4 was reported as a limit; the forecaster's own chance of this, stated with the estimate: 85%; the middle value is on the limit's open side.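

In this assay compound 4 returns only a limit, > 25000 nM, and not a number. For the compounds shown here, compound 3 also stands at a limit, so no step from compound 3 to compound 4 can be read. The compounds shown leave open what number either compound 3 or compound 4 has, and so whether chloro in place of hydrogen on an aromatic carbon changes the read-out on the core of compound 3 at all.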